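The compounds below may be only part of what the source reports. "The series", "measured", "known", "first", "only" and "open" are said of these compounds alone.

In a functional assay on MCF7 cells (Homo sapiens) for cytotoxicity, read by MTT assay, with a stated time of 48 h (on this read-out lower numbers stand for stronger inhibition and higher numbers for weaker inhibition), compound 1 `C=C1CCC[C@]2(C)CCC(c3cn(-c4cccc([N+](=O)[O-])c4)nn3)=CC[C@@]12C` gives 40300 nM, compound 2 `C=C1CCC[C@]2(C)CCC(c3cn(-c4ccccc4C(C)=O)nn3)=CC[C@@]12C` gives 29900 nM and compound 3 `C=C1CCC[C@]2(C)CCC(c3cn(-c4cccc(OC)c4)nn3)=CC[C@@]12C` gives 56200 nM. Compound 3 cannot be told apart from the other two, as a 1.4-fold higher number from compound 1 to compound 3 (0.14 log units; within the scatter) and a 1.9-fold higher number from compound 2 to compound 3 (0.27 log units; within the scatter) both lie within the scatter. Compound 4 `C=C1CCC[C@]2(C)CCC(c3cn(-c4ccc(C)cc4)nn3)=CC[C@@]12C` differs from compound 3 by one change: 4-methylphenyl in place of 3-methoxyphenyl on an aromatic nitrogen. Within the data shown here, no measured compound carries 4-methylphenyl, but the closest evidence is the exchange of groups at this same aromatic nitrogen. Those two steps, a 1.9-fold higher number from compound 2 to compound 3 (0.27 log units; within the scatter) and a 1.3-fold lower number from compound 1 to compound 2 (0.13 log units; within the scatter), stayed within the scatter, so no step beyond it is expected in this assay. The expected step is a 1.4-fold lower number from compound 3 to compound 4 (0.15 log units; within the scatter), which is within the scatter. For compound 4 the estimated value is 40000 nM, with an expected range from 20000 nM to 80000 nM.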

Compound 4, half-maximal inhibitory concentration: 54900 nM
Compound 4: middle estimate off by 1.4-fold (0.14 log units), on the low side; the range from low to high includes it.
By their numbers in this assay, from the lowest: compounds 2, 1, 4 and 3 (each within the scatter of the next).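

Placing 4-methylphenyl on this aromatic nitrogen gives a 1.0-fold lower number from compound 3 to compound 4 (0.01 log units; within the scatter) and a 1.8-fold higher number from compound 2 to compound 4 (0.26 log units; within the scatter) and a 1.4-fold higher number from compound 1 to compound 4 (0.13 log units; within the scatter) in this assay. A group with no hydrogen-bond acceptor, unlike 3-methoxyphenyl, therefore stays within the scatter of all three earlier groups, so this position has shown no measurable difference across the four phenyl groups. No measurement shown here offers an explanation for this result. Still open, from the compounds shown here alone, is whether a phenyl ring bearing an amine or a carboxylic acid, or a longer chain in place of the phenyl ring, would move the number beyond the scatter.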